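Working notes: from compound 3 to compound 4

The source may hold more compounds than are shown below. What is called first, only, known or untested is meant among the compounds shown, and "the series" means these compounds.

In a functional assay on U-373MG ATCC cells for cytotoxicity against U373 MG (Homo sapiens), read by colorimetric assay and MTT assay (a lower number here means a stronger inhibitor, a higher number a weaker inhibitor), compound 1 (`COc1cccc2cc(-c3ccccc3)c(O)nc12`) gives 10000 nM and compound 2 (`COc1cc(OC)c2cc(-c3ccccc3)c(O)nc2c1`) gives 10000 nM as well. Compound 3 (`CCN(CC)C(=O)Cn1c(=O)c(-c2ccc(OC)cc2)cc2c(OC)cc(OC)cc21`) reads 10000 nM in this assay and stands level with compound 1 and compound 2 at the digits available. Among the compounds with values here, no two measured compounds differ in one place only, so the series offers no measured step as a guide.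

Compound 4 (`COc1ccc(-c2cc3c(OC)cc(OC)cc3n(CCCC#N)c2=O)cc1`) keeps the core of compound 3 and changes its side chain. The change is 2-cyanoethyl in place of diethylcarbamoyl on a saturated chain carbon bound to an aromatic nitrogen and, cut one bond further out, it reads (diethylcarbamoyl)methyl to 3-cyanopropyl.

Within the data shown here, the only direct reference is compound 3 at 10000 nM in this assay and the other two measured compounds show the same value. The expected outcome is no change at the digits printed from compound 3 to compound 4 (within the scatter) and this estimate lies within the scatter. A larger step cannot be excluded and would be expected toward lower numbers. For compound 4 the estimated value is 10000 nM with an expected range from 3000 nM to 12000 nM in this assay as the working figure.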

Compound 4, half-maximal inhibitory concentration: 10000 nM
For compound 4 middle estimate and measured number coincide at the digits printed; the range from low to high includes it.
By their numbers in this assay, from the lowest: compounds 1, 2, 3 and 4 (each within the scatter of the next).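

In this assay, within the data shown here, the first step that differs in one place reads no change at the digits printed from compound 3 to compound 4 (within the scatter), with 2-cyanoethyl in place of diethylcarbamoyl on a saturated chain carbon bound to an aromatic nitrogen. At this position, then, exchanging the carbonyl-bearing group for the nitrile-bearing one, with its triple bond and fewer heavy atoms, leaves the read-out unmoved. No measurement at hand bears on why the number holds.

What the compounds shown leave open is whether any group at this place moves the number, for example a primary amine, a carboxylic acid or a longer chain in place of 2-cyanoethyl. Going by these compounds, whether the same exchange reads alike on a different core also stays open.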